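The source may hold more compounds than are shown below. What is called first, only, known or untested is meant among the compounds shown, and "the series" means these compounds.

Of the compounds shown here, three have so far been tested in a functional assay on MCF7 cells (Homo sapiens) for cytotoxicity, read by MTT assay, with a stated time of 72 h; on this read-out lower numbers stand for stronger inhibition of growth and higher numbers for weaker inhibition of growth. Compound 3 `O=C(/N=C(/NC(=O)c1cc2ccccc2s1)[Se]Cc1ccccc1)c1cc2ccccc2s1` gives 37900 nM in this assay. Compound 1 `C[Se]/C(=N\C(=O)c1cc2ccccc2s1)NC(=O)c1cc2ccccc2s1`, which carries hydrogen in place of phenyl on a saturated chain carbon bound to a selenium atom, gives 5070 nM in this assay, and that single change produced a 7.5-fold lower number from compound 3 to compound 1 (0.87 log units; beyond the scatter). Compound 2 `O=C(/N=C(/NC(=O)c1csc([N+](=O)[O-])c1)[Se]Cc1ccccc1)c1csc([N+](=O)[O-])c1` gives 24400 nM in this assay, a number that lies close to that of compound 3; the difference between the cores of compound 2 and compound 3 is not broken down here.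

Compound 4 `C[Se]/C(=N\C(=O)c1csc([N+](=O)[O-])c1)NC(=O)c1csc([N+](=O)[O-])c1` has not yet been measured. It differs from compound 2 by hydrogen in place of phenyl on a saturated chain carbon bound to a selenium atom, the same change, made at the same place, that separates compound 3 from compound 1. Among the measured compounds shown here, only that one earlier example of the change is available, so the expectation rests on compound 3 and compound 1 alone, where the change gave a 7.5-fold lower number from compound 3 to compound 1 (0.87 log units; beyond the scatter). Compound 4 is therefore estimated to give 4000 nM in this assay, with a likely span from 1500 nM to 12000 nM. The expected step of a 6.1-fold lower number from compound 2 to compound 4 (0.79 log units; beyond the scatter) is thus taken to resemble the earlier one in size.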

Compound 4, concentration for 50% growth inhibition: 0.76 nM
For compound 4 the middle estimate is 5300-fold (3.72 log units) above the measured one; measured number outside the range, below it.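

In this assay, the change from benzyl to methyl gave a 32000-fold lower number from compound 2 to compound 4 (4.51 log units; beyond the scatter), a lower number in the same direction as on the other core. Among the compounds shown here, the direction carried from one core to the other, but the size of the step did not: the same change on two cores in this assay, a 7.5-fold lower number (0.87 log units; beyond the scatter) from compound 3 to compound 1 and a 32000-fold lower number (4.51 log units; beyond the scatter) from compound 2 to compound 4, 4300-fold (3.63 log units) apart, beyond the scatter of two such steps With only two pairs, this shows that the size of the step depends on the core carrying it, but it does not show which part of the core is responsible or what the step would be on a further core.

The compounds shown leave open how an ethyl group or a longer chain on the selenium atom would behave on either core, and whether a sulfur atom in place of the selenium atom would keep the low number seen for compound 4. They also leave open whether the large step would survive with an amine in place of the nitro group.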